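The compounds below may be only part of what the source reports. "The series", "measured", "known", "first", "only" and "open" are said of these compounds alone.

Three compounds share the same amide-linked tail and differ in the core and in the group on a saturated chain carbon bound to a carbonyl carbon and an oxygen on a saturated carbon. Compound 3 `CC(C)(C)[C@@H](O)C(=O)N1C[C@H]2C[C@H]2[C@H]1C(=O)NCc1cc(Cl)ccc1-n1cnnn1` and compound 1 `CCCC[C@@H](O)C(=O)N1C[C@H]2C[C@H]2[C@H]1C(=O)NCc1cc(Cl)ccc1-n1cnnn1` have one core; compound 2 `CC(C)(C)[C@@H](O)C(=O)N1N=CC[C@H]1C(=O)NCc1cc(Cl)ccc1-n1cnnn1` has another, and the difference between the two cores is not broken down here. In an ADME assay on liver for metabolic stability, with Liver microsome (Homo sapiens) as the target, read by LC-MS, using microsomes (on this read-out higher numbers stand for fast clearance and lower numbers for slow clearance), compound 3 gives 22 mL.min-1.g-1, and compound 1 gives 32 mL.min-1.g-1. The change from compound 3 to compound 1 is butyl in place of tert-butyl on a saturated chain carbon bound to a carbonyl carbon and an oxygen on a saturated carbon, and it gave a 1.5-fold higher number from compound 3 to compound 1 (0.16 log units; within the scatter). Compound 2 in this assay reaches only a limit, < 12 mL.min-1.g-1, so no exact number is known for it; the limit is the limit of < 12 mL.min-1.g-1 in this assay, at which 1 of the 3 values shown sits. The unmeasured compound 4 `CCCC[C@@H](O)C(=O)N1N=CC[C@H]1C(=O)NCc1cc(Cl)ccc1-n1cnnn1` arises from compound 2 by the same change, (butyl in place of tert-butyl on a saturated chain carbon bound to a carbonyl carbon and an oxygen on a saturated carbon). The expected step is a number no lower from compound 2 to compound 4 (the limit leaves the size open), resting on a 1.5-fold higher number from compound 3 to compound 1 (0.16 log units; within the scatter) seen for the same change in this assay. Compound 4 is therefore estimated at 12 mL.min-1.g-1, with a likely range from 6 mL.min-1.g-1 to 25 mL.min-1.g-1.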

Compound 4, intrinsic clearance in microsomes: < 12 mL.min-1.g-1
Compound 4 was reported as a limit; the forecaster's own chance of this, stated with the estimate: 50%; the middle value lies on the limit itself.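

Compound 2 and compound 4 are both reported only as limits, not as exact numbers, so no step can be read between them: the limit of < 12 mL.min-1.g-1 in this assay, at which 2 of the 4 values shown sit.

The compounds shown leave open how large the change from tert-butyl to butyl is on the core of compound 2, and whether it matches the step seen on the core of compound 3.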